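The source may hold more compounds than are shown below. What is called first, only, known or untested is meant among the compounds shown, and "the series" means these compounds.

Compound 1 `NCC(O)Cn1c(=O)n(C2OC(CO)[C@@H](O)[C@H]2O)c2nc(N)nc(O)c21` gives the larger of the two responses recorded in a functional assay on the whole organism (B cells) with Mus musculus as the target (on this read-out lower numbers stand for smaller maximal responses and higher numbers for larger maximal responses), reaching 110%. Among the compounds with values here, the only other measured compound, compound 2 `C=CCn1c(=S)n(COCCO)c2nc(N)nc(O)c21`, stands far lower in this assay at 9%, a gap well beyond the usual scatter; since the two differ in more than one place, their values show only that the series spans a wide range. Compound 3 `Nc1nc(O)c2c(n1)n(C1OC(CO)[C@@H](O)[C@H]1O)c(=O)n2C/C=C/c1ccccc1` has not yet been measured. It differs from compound 1 in one place: 2-phenylethenyl in place of 2-amino-1-hydroxyethyl on a saturated chain carbon bound to an aromatic nitrogen. Within the data shown here, no measured pair isolates this change, so its effect is unknown. Compound 3 is expected to keep a clear response, though likely a reduced one, and the step from compound 1 to compound 3 is estimated at a number 45 percentage points lower from compound 1 to compound 3 (beyond the scatter), a decrease beyond the scatter. Compound 3 is therefore estimated to reach 65% in this assay, within a range from 15% to 115%.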

Compound 3, largest response reached (reported as maximal response), in percent of the reference or control that the assay uses: 73%
Estimate against measurement, compound 3: 8 percentage points below; low and high end bracket the measured number.
By their numbers in this assay, from the lowest: compound 2; then compound 3; then compound 1.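

In this assay, within the data shown here, replacing 2-amino-1-hydroxyethyl with 2-phenylethenyl on a saturated chain carbon bound to an aromatic nitrogen gives a clear drop, a number 37 percentage points lower from compound 1 to compound 3 (beyond the scatter), the first reading of this position with the rest of the molecule unchanged. The response does not depend fully on the amine and hydroxyl of the leaving group, as compound 3 still reaches 73%. Nothing available explains the size of this drop.

The compounds shown leave open which part of the change accounts for the loss, as the amine and hydroxyl leave together while the phenyl ring and double bond enter together. A 3-aminopropyl, 3-hydroxypropyl or saturated 3-phenylpropyl chain at this place would separate these parts.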